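Shrinking the Aryl Group on a Nucleoside Core

A few compounds are considered here, and "the series" means these few. Any claim that something is new, unique, unknown or untested is made for them only; others in the source may bear on it.

Of the compounds shown here, three have been measured in a functional assay on CEM-DNR-bulk cells (Homo sapiens), read by MTT assay, with a stated time of 72 h; a lower number here means a stronger inhibitor, a higher number a weaker inhibitor. Compound 1 `Nc1nc(N)c2c(-c3cc4ccccc4o3)cn([C@@H]3O[C@H](CO)[C@@H](O)[C@H]3O)c2n1` gives only a limit in this assay, > 20000 nM, not a number. Compound 2 `Cc1nc(N)c2c(-c3cc4ccccc4o3)cn([C@@H]3O[C@H](CO)[C@@H](O)[C@H]3O)c2n1` carries a methyl in place of the amino group, and in this assay compound 2 gives 6310 nM. That change is an at least 3.1-fold lower number from compound 1 to compound 2 (0.50 log units; beyond the scatter). Compound 3 `C#Cc1cn([C@@H]2O[C@H](CO)[C@@H](O)[C@H]2O)c2ncnc(C)c12`, built on a different core, gives 160 nM in this assay. Compound 2 therefore stands at the higher of the two numbers shown, with compound 3 far lower.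

Compound 4 `Cc1nc(N)c2c(-c3ccoc3)cn([C@@H]3O[C@H](CO)[C@@H](O)[C@H]3O)c2n1` differs from compound 2 in one place: furan-3-yl in place of 1-benzofuran-2-yl on an aromatic carbon. Among the measured compounds shown here, none of the measured steps concerns this aryl group: the step from compound 1 to compound 2 changes the amino group, and compound 3 differs in its core and in the group it carries. No measured step therefore bears on the change, and its direction cannot be read from the numbers shown. The expectation is that compound 4 stays close to compound 2, with an expected step of a 1.3-fold higher number from compound 2 to compound 4 (0.10 log units; within the scatter) in this assay, inside a wide range. In this assay compound 4 is therefore estimated at 8000 nM, expected to lie between 1500 nM and 25000 nM.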

Compound 4, half-maximal inhibitory concentration: > 20000 nM
Compound 4 ended at the assay's limit (the forecaster's own chance of this, stated with the estimate: 25%); middle value at least 2.5-fold (0.39 log units) away from the limit.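

Replacing 1-benzofuran-2-yl with furan-3-yl on this aromatic carbon removes the six-membered aromatic ring and gives an at least 3.1-fold higher number from compound 2 to compound 4 (0.50 log units; beyond the scatter) in this assay, so the result in this cell assay depends on which aryl group sits at this position. Compound 4 gives > 20000 nM, which is a limit of the assay and not a number, so the step has a known minimum but no known true size. The earlier step changed only the amino group, which makes this the first measured sign that the aryl group matters, and of the two aryl groups compared here, only the two-ring group gives a value that can be read as a number: the limit of > 20000 nM in this assay, at which 2 of the 4 values shown sit.

This single step changes both the ring count and the point of attachment on the furan, and the compounds shown do not separate these two changes. A furan-2-yl group at the same place would test the point of attachment alone, while a phenyl or naphthalen-2-yl group would show whether another six-membered aromatic ring can restore a readable value.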